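Replacing a Diol Side Chain with a Piperidine

A few compounds are considered here, and "the series" means these few. Any claim that something is new, unique, unknown or untested is made for them only; others in the source may bear on it.

Three compounds share one core and differ only at a saturated chain carbon bound to a saturated ring carbon. In a functional assay on LNCaP cells (Homo sapiens) for antiproliferative activity (on this read-out lower numbers stand for stronger inhibition and higher numbers for weaker inhibition), compound 1 `Cn1ncc(Cl)c1-c1cc(C(=O)N[C@@H]2CN[C@H](CC(=O)NC3CC3)C[C@H]2c2ccc(Cl)c(Cl)c2)oc1Cl` gives 190 nM, compound 2 `COCC[C@@H]1C[C@@H](c2ccc(Cl)c(Cl)c2)[C@H](NC(=O)c2cc(-c3c(Cl)cnn3C)c(Cl)o2)CN1` gives 250 nM, and compound 3 `Cn1ncc(Cl)c1-c1cc(C(=O)N[C@@H]2CN[C@H](CC(O)CO)C[C@H]2c2ccc(Cl)c(Cl)c2)oc1Cl` gives 70 nM, the lowest of the three. Compound 4 `Cn1ncc(Cl)c1-c1cc(C(=O)N[C@@H]2CN[C@H](CCN3CCCCC3)C[C@H]2c2ccc(Cl)c(Cl)c2)oc1Cl` removes the 1,2-dihydroxyethyl group of compound 3: (piperidin-1-yl)methyl in place of 1,2-dihydroxyethyl on a saturated chain carbon bound to a saturated ring carbon. Because a 2.7-fold lower number from compound 1 to compound 3 (0.43 log units; beyond the scatter) and a 3.6-fold lower number from compound 2 to compound 3 (0.55 log units; beyond the scatter) both show a modest gain on arrival of the diol, its departure in favour of a group with no hydrogen-bond donors is expected to give a modest rise in the number, so the step of a 2.9-fold higher number from compound 3 to compound 4 (0.46 log units; beyond the scatter) is expected. Compound 4 is therefore estimated at 200 nM, with a range from 70 nM to 600 nM.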

Compound 4, half-maximal inhibitory concentration: 1780 nM
Compound 4: middle estimate off by 8.9-fold (0.95 log units), on the low side, and the stated range ends below it.
By their numbers in this assay, from the lowest: compound 3; then compounds 1 and 2 (each within the scatter of the next); then compound 4.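

Going by these compounds alone, the position proved far more sensitive than the earlier compounds suggested: swapping the diol for the piperidine gives a 25-fold higher number from compound 3 to compound 4 (1.41 log units; beyond the scatter) and a large loss of inhibition. Compound 4 also falls behind the side chains without a diol, with a 7.1-fold higher number from compound 2 to compound 4 (0.85 log units; beyond the scatter) and a 9.4-fold higher number from compound 1 to compound 4 (0.97 log units; beyond the scatter) as the modest steps that show it. Nothing available here explains this drop. On these data alone, whether it comes from the piperidine ring itself or from its nitrogen stays open. An open-chain dimethylamino group or a cyclohexyl ring at this position would help separate the two.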